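A few compounds are considered here, and "the series" means these few. Any claim that something is new, unique, unknown or untested is made for them only; others in the source may bear on it.

Compound 1, `CC(=O)OCOC(=O)N(C)/N=N/c1ccc(C#N)cc1`, was tested in an ADME assay on a cell-free system (plasma, Homo sapiens) for metabolic stability (on this read-out lower numbers stand for a shorter-lived compound and higher numbers for a longer-lived compound), where compound 1 gives 0.117 h. For the measured compounds named here, only one other compound stands beside it: compound 2, `CS(=O)(=O)N(COC(=O)c1ccccc1)c1ccc([N+](=O)[O-])cc1Oc1ccccc1`, which in this assay gives 0.0322 h. Going by the values given here, of these two numbers the one for compound 1 is the higher, and the gap between them lies beyond the usual scatter, so compound 1 is the longer-lived of the pair. Compound 2 differs from compound 1 in many places at once, so nothing can be read from that gap about any single change.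

Compound 3, `CC(=O)OCOC(=O)N(C)/N=N/c1ccc(C)cc1`, has not yet been measured in this assay. It differs from compound 1 in one place only, (methyl in place of cyano on an aromatic carbon), while the rest of the molecule is kept. Among the compounds with values here, no measured pair in this set tells how such a change acts on the half-life, so the expectation rests on the value of compound 1 alone. The step from compound 1 to compound 3 is expected to be small, a 1.1-fold higher number from compound 1 to compound 3 (0.05 log units; within the scatter), within the usual scatter and without a clear direction. For compound 3 the half-life is therefore estimated at 0.13 h, with a range from 0.05 h to 0.35 h.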

Compound 3, half-life: 0.25 h
The estimate for compound 3 lay 1.9-fold (0.28 log units) below the measured number, within the range that was stated.
By their numbers in this assay, from the lowest: compound 2; then compound 1; then compound 3.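

In this assay, methyl in place of cyano on an aromatic carbon, para to a large group, gives a 2.1-fold higher number from compound 1 to compound 3 (0.33 log units; beyond the scatter), a modest step but one beyond the scatter. For the compounds shown here, this is the first pair in the set that differs in one place only, so for the first time a change in the half-life can be tied to a single spot: with the rest of the molecule kept, the group on this ring carbon matters, and here the compound with methyl is the longer-lived of the two. The data shown offer no measurement that explains the step.

A single pair cannot separate what the loss of the cyano group contributes from what the arrival of the methyl group contributes, and it leaves open how a bare ring hydrogen, a chlorine atom, a methoxy group, an amine, a carboxylic acid or a longer chain such as ethyl would fare on this carbon. Going by these compounds, whether the same swap would move the half-life in the same direction on a different core also stays open.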